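The source may report more compounds than this note shows. Statements on the series, on what has been measured and on what is new or still open speak of the compounds shown alone.

Compound 1, `CS(=O)(=O)CCn1c(Cn2c(S(C)(=O)=O)cc3ccccc32)nc2ccccc21`, was tested in an ADME assay on HEp-2 cells (Homo sapiens) for cytotoxicity, with a stated time of 4 days; on this read-out higher numbers stand for lower toxicity in this test and lower numbers for higher toxicity in this test. For compound 1 the result is only a limit, > 100000 nM. Compound 2, `CC(C)(O)CCn1c(Cn2nc(S(C)(=O)=O)c3ccncc32)nc2cc(Cl)ccc21`, likewise reaches only a limit in this assay, > 100000 nM. Both results sit at the limit of > 100000 nM in this assay, at which 2 of the 2 values shown sit, so compound 2 stands level with the one other compound shown. Compound 3, `CS(=O)(=O)c1nn(Cc2nc3cc(Cl)ccc3n2CC2COC2)c2cnccc12`, differs from compound 2 by oxetan-3-yl in place of 2-hydroxy-2-methylpropyl on a saturated chain carbon bound to an aromatic nitrogen. Among the compounds with values here, no measured pair differs in just one place, so the expected step is an estimate, a step that the limit leaves unreadable from compound 2 to compound 3, with no change beyond the scatter. Compound 3 is expected to give about 150000 nM, within 60000 nM to 400000 nM, probably again reported only as a limit.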

Compound 3, half-maximal cytotoxic concentration in the HEp-2 assay: > 100000 nM
Compound 3 gave a limit, no number; the forecaster's own chance of this, stated with the estimate: 85%; the middle value does not contradict the limit.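

In the HEp-2 assay compound 2 gives only a limit (> 100000 nM). In the HEp-2 assay compound 3 also gives only a limit (> 100000 nM). Within the data shown here, no step between them can be read. The compounds shown leave open at what concentration, if any, each becomes toxic to these cells. In a physicochemical assay for solubility, read by spectrophotometry, in phosphate buffer, at pH 6.5 (a lower number here means a less soluble compound, a higher number a more soluble compound), compound 2 gives 41 ug/mL and compound 3 gives 4 ug/mL (a 10-fold lower number from compound 2 to compound 3 (1.01 log units; beyond the scatter)).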